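Replacing a Methyl with an Isopropyl at the Sensitive Position

This account rests on a few compounds, and the source may have more. Where it says the series, first, only, none or still open, it means among the compounds named here.

Compound 1 `Cc1cn(-c2cc(NC(=O)c3ccc(C)c(Nc4nc(-c5cccnc5)cs4)c3)cc(C(F)(F)F)c2)cn1`: 30 nM
Compound 2 `Cc1ccc(C(=O)Nc2cc(-n3ccnc3)cc(C(F)(F)F)c2)cc1Nc1nc(-c2cccnc2)cs1`: 36 nM
Compound 3 `Cc1cc(NC(=O)c2ccc(C)c(Nc3nc(-c4cccnc4)cs3)c2)cc(-n2cnc(C)c2)c1`: 871 nM

In a functional assay on KU812 cells (Homo sapiens) for antiproliferative activity (a lower number here means a stronger inhibitor, a higher number a weaker inhibitor), compound 3 gives the highest number of the three: its step from compound 1 is a 29-fold higher number from compound 1 to compound 3 (1.46 log units; beyond the scatter), and its gap to compound 2 is of much the same size. Compound 4 `Cc1cn(-c2cc(NC(=O)c3ccc(C)c(Nc4nc(-c5cccnc5)cs4)c3)cc(C(C)C)c2)cn1` differs from compound 3 by isopropyl in place of methyl on an aromatic carbon. Among the compounds with values here, one measured step touches this place, a 29-fold higher number from compound 1 to compound 3 (1.46 log units; beyond the scatter), which shows that the group on this carbon moves the number strongly. The other step, a 1.2-fold higher number from compound 1 to compound 2 (0.08 log units; within the scatter), lies elsewhere and stays within the scatter. Because compound 3 lost so much in a 29-fold higher number from compound 1 to compound 3 (1.46 log units; beyond the scatter), a further change at the same place is expected to shift the number again, most likely downward. Compound 4 is therefore estimated at 120 nM (range 30 nM to 500 nM), an expected step of a 7.3-fold lower number from compound 3 to compound 4 (0.86 log units; beyond the scatter).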

Compound 4, half-maximal inhibitory concentration: 51 nM
Beside the measured number, compound 4's estimate is 2.4-fold (0.37 log units) above it, within the range that was stated.
By their numbers in this assay, from the lowest: compounds 1, 2 and 4 (each within the scatter of the next); then compound 3.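

In this assay, this carbon does not depend on trifluoromethyl: the change to isopropyl gives a 17-fold lower number from compound 3 to compound 4 (1.23 log units; beyond the scatter), reversing the loss seen with methyl, while a 1.7-fold higher number from compound 1 to compound 4 (0.23 log units; within the scatter). Among these groups, then, only methyl stands apart, and a carbon-only group can match the fluorinated one. Nothing available here explains why isopropyl and trifluoromethyl match while methyl does not. From the compounds shown here alone, it remains open whether an ethyl group, a tert-butyl group or an amine at this carbon would track isopropyl or methyl.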